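Methyl for Cyclopropyl on the Propargylic Carbon

The source may report more compounds than this note shows. Statements on the series, on what has been measured and on what is new or still open speak of the compounds shown alone.

Measured in a functional assay on HBL-100 cells (Homo sapiens) for antiproliferative activity, read by sulforhodamine B assay, with a stated time of 48 h; on this read-out lower numbers stand for stronger inhibition of growth and higher numbers for weaker inhibition of growth:
Compound 1 `COC(=O)C#CC(O/C=C/C(=O)OC)C1CC1`: 250 nM
Compound 3 `CCOC(=O)C#CC(C[C@@H](C)CCC=C(C)C)O/C=C/C(=O)OCC`: 2600 nM
Compound 2 `CC1CCC(C(C)C)C(OC(=O)C#CC(O/C=C/C(=O)OC2CC(C)CCC2C(C)C)C(C)C)C1`: > 100000 nM, which is the limit of > 100000 nM in this assay, at which 1 of the 3 values shown sits, and not a number.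

Compound 1 holds the lowest of the two numbers; compound 3 lies higher, beyond the scatter, and compound 2 gives only a limit. Compound 4 `COC(=O)C#CC(C)O/C=C/C(=O)OC` has not been measured. It differs from compound 1 in one place: methyl in place of cyclopropyl on a saturated chain carbon bound to an oxygen on an unsaturated carbon and a triple-bonded carbon. Within the data shown here, no pair of measured compounds differs in exactly that way, so the size of the step is not known. Since a larger substituent in compound 3 goes with the higher number 2600 nM, the smaller methyl is expected to give a number near that of compound 1 or somewhat higher. For compound 4 the estimate is 500 nM, between 150 nM and 2500 nM, a step from compound 1 of a 2.0-fold higher number from compound 1 to compound 4 (0.30 log units; within the scatter).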

Compound 4, concentration for 50% growth inhibition: 300 nM
The estimate for compound 4 lay 1.7-fold (0.22 log units) above the measured number, and the stated range covers the measured number.
By their numbers in this assay, from the lowest: compounds 1 and 4 (each within the scatter of the next); then compound 3. At a limit, above all of these: compound 2.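

In this assay methyl in place of cyclopropyl on a saturated chain carbon bound to an oxygen on an unsaturated carbon and a triple-bonded carbon gives a 1.2-fold higher number from compound 1 to compound 4 (0.08 log units; within the scatter) and so leaves the number within the scatter. At this position, then, the three-membered ring can give way to methyl with no change that can be read. Nothing measured here bears on why this is so.

The compounds shown leave open what a hydrogen, a longer straight chain or an amine would give on this carbon with the rest of compound 4 kept.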